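From ethyl(methyl)amino to cyclopropylamino: a small expected step

This account rests on a few compounds, and the source may have more. Where it says the series, first, only, none or still open, it means among the compounds named here.

- Compound 1 `O=C(/C=C1\CCc2ccccc21)NC1CC1` gives 150 mg/kg
- Compound 2 `CC(C)NC(=O)/C=C1\CCc2ccc(F)cc21` gives 96 mg/kg
- Compound 3 `CCN(C)C(=O)/C=C1\CCc2ccc(F)cc21` gives 100 mg/kg

These three compounds are tested in a functional assay on the whole organism with Mus musculus as the target (a lower number here means that less compound is needed, a higher number that more compound is needed for the effect), and their numbers sit close together. Compound 3 at 100 mg/kg lies within the usual scatter of both compound 1 and compound 2, so repeat testing alone could produce gaps of this size.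

The next compound is compound 4 `O=C(/C=C1\CCc2ccc(F)cc21)NC1CC1` and the change is confined to the group on the carbonyl carbon, where cyclopropylamino takes the place of ethyl(methyl)amino. In numbers, the change is cyclopropylamino in place of ethyl(methyl)amino on a carbonyl carbon and this is a swap of similar size that adds a ring.

For the measured compounds named here, the only measured step of this kind is a 1.0-fold higher number from compound 2 to compound 3 (0.02 log units; within the scatter) and it exchanges isopropylamino for ethyl(methyl)amino without leaving the scatter. Compound 1 also carries cyclopropylamino and its value of 150 mg/kg stays within the scatter of compound 3 as well. Neither observation points to a large step, though the evidence is thin.

The estimated step is a 1.1-fold higher number from compound 3 to compound 4 (0.04 log units; within the scatter) and so no change beyond the scatter is expected in this assay for this swap. Compound 4 is thus estimated at 110 mg/kg with an expected range of 60 mg/kg to 200 mg/kg for repeat measurements.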

Compound 4, dose for half-maximal effect: 66 mg/kg
Compound 4: middle estimate off by 1.7-fold (0.22 log units), on the high side; the range from low to high includes it.
By their numbers in this assay, from the lowest: compounds 4, 2, 3 and 1 (each within the scatter of the next, the first and the last beyond it).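

With the fluoro-bearing core held fixed, the new compound shows that cyclopropylamino on the carbonyl carbon does not clearly separate from either open-chain group in this assay: the swap gives a 1.5-fold lower number from compound 3 to compound 4 (0.18 log units; within the scatter) and, against isopropylamino, a 1.5-fold lower number from compound 2 to compound 4 (0.16 log units; within the scatter). The ring and the hydrogen-bond donor that enter with cyclopropylamino therefore bring no step beyond the scatter here. With cyclopropylamino held fixed instead, fluoro in place of hydrogen on an aromatic carbon gives a 2.3-fold lower number from compound 1 to compound 4 (0.36 log units; beyond the scatter), a modest step and the only one so far that leaves the scatter. Nothing measured alongside these numbers explains this step.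

As far as these compounds go, this fluoro effect rests on a single pair, so it remains open whether the same swap would give a similar step with isopropylamino or ethyl(methyl)amino on the carbonyl carbon. From the compounds shown here alone, how the number would respond to chloro or methoxy in place of fluoro, or to cyclobutylamino in place of cyclopropylamino, also remains open.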